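The source may hold more compounds than are shown below. What is called first, only, known or untested is meant among the compounds shown, and "the series" means these compounds.

Compounds measured in a physicochemical assay for lipophilicity, using the shake flask method, measured as octanol-water partition, at 23 degrees C; a higher number here means a more lipophilic compound, a lower number a more polar compound:
compound 1, `CN/C(=N\C#N)NCc1ccc(Cl)nc1`: 0.84
compound 2, `CN(C)/C(=N\C#N)NCc1ccc(Cl)nc1`: 0.66

Compound 1 gives the highest of the two numbers in this assay; its nearest neighbour is compound 2, reached by a methyl in place of hydrogen on an amine nitrogen, and the step is a number 0.18 log units lower from compound 1 to compound 2 (within the scatter). Compound 3, `CN/C(=N\C#N)N(C)Cc1ccc(Cl)nc1`, has not yet been measured in this assay. Its difference from compound 1 is methyl in place of hydrogen on an amine nitrogen. Within the data shown here, the only measured step that bears on this is the one from compound 1 to compound 2, which also replaced an amine hydrogen by methyl and stayed within the scatter. Among the measured compounds shown here, no step of the same kind at this particular nitrogen has been measured. The account therefore expects a step of a number 0.09 log units lower from compound 1 to compound 3 (within the scatter) for compound 3, small enough to sit within the scatter. For compound 3 the estimate in this assay is 0.75, with a range from 0.35 to 1.25.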

Compound 3, partition coefficient: 0.78
The estimate for compound 3 lay 0.03 log units below the measured number, within the range that was stated.
By their numbers in this assay, from the lowest: compounds 2, 3 and 1 (each within the scatter of the next).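

In this assay, methyl in place of hydrogen on the amine nitrogen whose other neighbours are a carbon with a double bond to nitrogen and a saturated chain carbon gives a number 0.06 log units lower from compound 1 to compound 3 (within the scatter) and so leaves the number within the scatter at this position too. The earlier compounds shown here showed the same change only at the other amine nitrogen, with a number 0.18 log units lower from compound 1 to compound 2 (within the scatter) and thus no step beyond the scatter at either place. Nothing measured here gives a reason for this result.

The compounds shown leave open whether an ethyl group, a longer chain or an acetyl group on this amine nitrogen would also stay within the scatter of compound 1. They also leave open what methyl on both amine nitrogens together would give.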